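Replacing the Nitrophenyl Sulfonamide Arm of Compound 3

A few compounds are considered here, and "the series" means these few. Any claim that something is new, unique, unknown or untested is made for them only; others in the source may bear on it.

Measured compounds:
compound 1 `COc1ccccc1C(=O)NCc1ccc(CNS(=O)(=O)c2ccc([N+](=O)[O-])cc2)cc1`: 100 nM
compound 2 `O=C(NCc1ccc(CNS(=O)(=O)c2ccccc2F)cc1)c1cccnc1`: 100 nM
compound 3 `Cc1ccccc1C(=O)NCc1ccc(CNS(=O)(=O)c2ccc([N+](=O)[O-])cc2)cc1`: 100 nM

In an assay on MDA-MB-231 cells for displacement of a labelled ligand from C-X-C chemokine receptor type 4 (Homo sapiens), read by fluorescence and microscopy, with stated times of 10 min and 30 min (on this read-out higher numbers stand for an effect only at larger amounts of compound and lower numbers for an effect already at smaller amounts), compound 3 gives 100 nM, level with compound 1 and compound 2. Within the data shown here, the one step with a single change, no change at the digits printed from compound 1 to compound 3 (within the scatter), touched the amide side and stayed within the scatter. Compound 4 `Cc1cccc(S(=O)(=O)NCc2ccc(CNC(=O)c3ccccc3C)cc2)c1` differs from compound 3 by 3-methylphenyl in place of 4-nitrophenyl on a sulfonyl sulfur. Among the measured compounds shown here, no measured step alters the aryl group on the sulfonyl sulfur, so the case rests on compound 2, which carries a different aryl there yet shows the same value as compound 3; a third aryl is therefore expected to sit close as well. The step of a 1.2-fold higher number from compound 3 to compound 4 (0.08 log units; within the scatter) is estimated to stay within the scatter, and compound 4 is expected to give 120 nM, between 40 nM and 400 nM.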

Compound 4, effective concentration (reported as EC, without a stated level of effect): 1000 nM
The estimate for compound 4 lay 8.3-fold (0.92 log units) below the measured number; the whole stated range lies below it.
By their numbers in this assay, from the lowest: compounds 1, 2 and 3 (each within the scatter of the next); then compound 4.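

In this assay, the aryl group on the sulfonyl sulfur proves sensitive to change: 3-methylphenyl in place of 4-nitrophenyl gives a 10-fold higher number from compound 3 to compound 4 (1.00 log units; beyond the scatter), the first step shown beyond the scatter. The earlier single change, on the amide side, had stayed within it. No available evidence bears on this step. The compounds shown leave open whether the step follows from losing the nitro group, gaining the methyl group or moving the substituent. An unsubstituted phenyl, 4-methylphenyl, 3-nitrophenyl or 4-cyanophenyl on the same sulfur would begin to separate these.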